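Hydroxy for Cyclohexyl on the Amide Nitrogen of Compound 2

The compounds below may be only part of what the source reports. "The series", "measured", "known", "first", "only" and "open" are said of these compounds alone.

compound 1 `CCN(Cc1ccoc1)C(=O)COc1ccc(C)cc1` 136 nM
compound 2 `Cc1ccc(OCC(=O)N(Cc2cccs2)C2CCCCC2)cc1` 40000 nM
compound 3 `CCN(Cc1cccn1C)C(=O)COc1ccc(C)cc1` 21300 nM

In an assay on HEK293 cells for agonist activity at transient receptor potential cation channel subfamily M member 8 (Homo sapiens), read by fluorescence and calcium flux, with a stated time of 15 min (a higher number here means that more compound is needed for the effect, a lower number that less compound is needed), compound 2 gives 40000 nM, within the scatter of compound 3 and far from compound 1. Compound 4 `Cc1ccc(OCC(=O)N(O)Cc2cccs2)cc1` differs from compound 2 by hydroxy in place of cyclohexyl on an amide-type nitrogen. Within the data shown here, the single measured step, a 160-fold higher number from compound 1 to compound 3 (2.19 log units; beyond the scatter), alters a ring on the saturated chain carbon rather than the group on the amide nitrogen, so it does not bear directly on this change. Compound 1 and compound 3 both carry ethyl on that nitrogen yet differ widely, so the nitrogen substituent alone does not fix the number. The expected step is a 1.3-fold lower number from compound 2 to compound 4 (0.12 log units; within the scatter), essentially none beyond the scatter. Compound 4 is estimated at 30000 nM, within 5000 nM to 150000 nM.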

Compound 4, half-maximal effective concentration: 8000 nM
Compound 4: the middle estimate sits 3.8-fold (0.57 log units) above what was measured; low and high end bracket the measured number.
By their numbers in this assay, from the lowest: compound 1; then compound 4; then compounds 3 and 2 (each within the scatter of the next).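

In this assay, among these compounds, the change of hydroxy for cyclohexyl on the amide-type nitrogen gives a 5.0-fold lower number from compound 2 to compound 4 (0.70 log units; beyond the scatter), the first measured step at this position. It shows that the group on this nitrogen can move the number beyond the scatter, and that here a smaller group with no ring goes with a lower number. Nothing measured here accounts for this step. Going by these compounds, what remains open is how a methoxy group, an amine or a longer chain on this nitrogen would compare with hydroxy, and whether the step would hold with another ring on the saturated chain carbon.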